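The compounds below may be only part of what the source reports. "The series", "measured", "known", "first", "only" and "open" are said of these compounds alone.

Three compounds share one core, which carries a variable group on an aromatic carbon of the five-membered ring with two nitrogen atoms. Compound 1 `CCCn1c(=O)c2nc([C@H]3CC4C=CC3C4)[nH]c2n(CCC)c1=O` and compound 2 `CCCn1c(=O)c2nc([C@@H]3CC4CCC3C4)[nH]c2n(CCC)c1=O` each bear a group of two five-membered non-aromatic rings of carbon only; in an assay on cell membranes for binding affinity to adenosine receptor A1 (Cavia porcellus), read by radioligand binding (a lower number here means a stronger inhibitor, a higher number a weaker inhibitor), compound 1 gives 3.4 nM and compound 2 gives 3.8 nM, a step of a 1.1-fold higher number from compound 1 to compound 2 (0.05 log units; within the scatter). Compound 3 `CCCn1c(=O)c2nc(-c3cccn3C)[nH]c2n(CCC)c1=O` carries the 1-methyl-1H-pyrrol-2-yl group instead and gives 140 nM in this assay, the highest of the three numbers, reached by a 41-fold higher number from compound 1 to compound 3 (1.61 log units; beyond the scatter) and a 37-fold higher number from compound 2 to compound 3 (1.57 log units; beyond the scatter).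

Compound 4 `CCCn1c(=O)c2nc(CC(C)(C)C)[nH]c2n(CCC)c1=O` differs from compound 3 by neopentyl in place of 1-methyl-1H-pyrrol-2-yl on an aromatic carbon. Within the data shown here, no measured step contains a neopentyl group, so the two large steps from compounds 1 and 2 to compound 3 are the only guide: they show that the group at this position moves the number far, and that the aromatic ring bearing one nitrogen sits at the weak end. Compound 4 is therefore expected to return part of the way toward compounds 1 and 2, a step of a 4.7-fold lower number from compound 3 to compound 4 (0.67 log units; beyond the scatter) in this assay. The estimate for compound 4 is 30 nM, with a range from 8 nM to 120 nM.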

Compound 4, inhibition constant: 49 nM
Compound 4: middle estimate off by 1.6-fold (0.21 log units), on the low side; the range from low to high includes it.
By their numbers in this assay, from the lowest: compounds 1 and 2 (each within the scatter of the next); then compound 4; then compound 3.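

In this assay, the step of a 2.9-fold lower number from compound 3 to compound 4 (0.46 log units; beyond the scatter) shows that at this position, on an aromatic carbon between two ring nitrogen atoms, a group need not contain a ring to give a lower number than compound 3: neopentyl, with only carbon and no hydrogen-bond acceptor, does so. Neopentyl still falls well short of the two groups made of five-membered non-aromatic rings, with a step of a 13-fold higher number from compound 2 to compound 4 (1.11 log units; beyond the scatter) and another of a 14-fold higher number from compound 1 to compound 4 (1.16 log units; beyond the scatter), so an open carbon group of this size does not reach the level of compound 1 or compound 2. Nothing available explains this order among the groups at this position.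

Neopentyl differs from the groups in compound 1 and compound 2 both in having no ring and in its number of carbon atoms, so the compounds shown cannot separate these two differences. A cyclopentyl group or a longer chain such as n-hexyl would bear on that question, and an amine on such a chain would test whether this position accepts a nitrogen outside a ring.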